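The compounds below may be only part of what the source reports. "The series", "measured", "known", "first", "only" and "open" are said of these compounds alone.

In an ADME assay on MT2 cells (Homo sapiens) for cytotoxicity (on this read-out higher numbers stand for lower toxicity in this test and lower numbers for higher toxicity in this test), compound 1 `C/C=C/COc1cc(Nc2ncccn2)ccc1Cl` gives 31000 nM. Within the data shown here, compound 2 `C/C=C/COc1cc(Nc2nccc(OC)n2)ccc1Cl` gives 17000 nM in this assay, and the only step measured so far is a 1.8-fold lower number from compound 1 to compound 2 (0.26 log units; within the scatter). Compound 2 stands at one end of these two numbers, but since the gap to compound 1 lies within the scatter, no real order between them can be read. Compound 3 `COc1ccnc(Nc2ccc(Cl)c(Oc3ccc(C)cc3)c2)n1` differs from compound 2 in a single place: 4-methylphenyl in place of but-2-en-1-yl on an oxygen on an aromatic ring. Among the measured compounds shown here, the one measured step, a methoxy replacing a hydrogen, touches another part of the shared core and carries no information about exchanging the but-2-en-1-yl for a 4-methylphenyl. For the measured compounds named here, with no comparable step to draw on, the expectation for this assay is a step of no change at the digits printed from compound 2 to compound 3 (within the scatter) that does not go beyond the scatter. Compound 3 is therefore estimated to give 17000 nM in this assay, with a range from 6000 nM to 50000 nM.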

Compound 3, half-maximal cytotoxic concentration: > 100000 nM
Compound 3: no number, only a limit; the forecaster's own chance of this, stated with the estimate: 10%; at least 5.8-fold (0.76 log units) between middle value and limit.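

In this assay, exchanging but-2-en-1-yl for 4-methylphenyl on the oxygen gives an at least 5.8-fold higher number from compound 2 to compound 3 (0.76 log units; beyond the scatter), the only step shown that lies beyond the scatter, so what sits on this oxygen does matter for the read-out. The change moves the number towards lower toxicity in this test, with an aromatic ring replacing an open chain that holds a double bond. The value of compound 3, > 100000 nM, is a limit of the assay and not a number, so the step gives only a minimum size: the limit of > 100000 nM in this assay, at which 1 of the 3 values shown sits.

The compounds shown do not tell whether the ring itself or the methyl on it accounts for the step. A plain phenyl or a saturated butyl chain on the same oxygen would help to separate these two parts of the change.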